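A few compounds are considered here, and "the series" means these few. Any claim that something is new, unique, unknown or untested is made for them only; others in the source may bear on it.

Measured so far in a functional assay on PC-3 cells (Homo sapiens) for inhibition, read by sulforhodamine B assay; a lower number here means a stronger inhibitor of growth, a higher number a weaker inhibitor of growth:
Compound 1 `Cc1ccc2[nH]c(-c3ccc(-c4ccc(-c5cccc(Cl)c5)cc4)cc3)nc2c1` gives 2670 nM
Compound 2 `COc1ccc(-c2ccc(-c3ccc(-c4nc5ccccc5[nH]4)cc3)cc2)cc1` gives 100000 nM
Compound 3 `CN(C)c1ccc(-c2ccc(-c3ccc(-c4nc5ccccc5[nH]4)cc3)cc2)cc1` gives 100000 nM

Compound 3 sits level with compound 2 at the highest of these three numbers, while compound 1 lies far lower, well beyond the scatter. The next compound to consider is compound 4 `Clc1cccc(-c2ccc(-c3ccc(-c4nc5ccccc5[nH]4)cc3)cc2)c1`, in which 3-chlorophenyl takes the place of 4-(dimethylamino)phenyl on an aromatic carbon (3-chlorophenyl in place of 4-(dimethylamino)phenyl on an aromatic carbon).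

For the measured compounds named here, only one measured step involves a single change, and it shows no change at the digits printed from compound 2 to compound 3 (within the scatter) as methoxy gives way to dimethylamino. That step does not test a 3-chlorophenyl, so it offers little guidance here. The closest evidence is compound 1 at 2670 nM, which carries the same 3-chlorophenyl and also has a methyl group on the shared core. No measurement isolates the effect of that methyl group, so the value of compound 1 is only a rough guide. In this assay a clear fall in the number, beyond the scatter, is therefore expected. The expected size of the change is a 17-fold lower number from compound 3 to compound 4 (1.22 log units; beyond the scatter). The estimate for compound 4 is 6000 nM, with an expected range from 1500 nM to 50000 nM.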

Compound 4, concentration for 50% growth inhibition: 33700 nM
Compound 4: the middle estimate sits 5.6-fold (0.75 log units) below what was measured; the measured number falls inside the stated range.
By their numbers in this assay, from the lowest: compound 1; then compound 4; then compounds 2 and 3 (each within the scatter of the next).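

In this assay, the group at this place can move the number after all: 3-chlorophenyl in place of 4-(dimethylamino)phenyl gives a 3.0-fold lower number from compound 3 to compound 4 (0.47 log units; beyond the scatter) and 3-chlorophenyl in place of 4-methoxyphenyl gives a 3.0-fold lower number from compound 2 to compound 4 (0.47 log units; beyond the scatter), whereas the earlier swap of methoxy for dimethylamino gave only no change at the digits printed from compound 2 to compound 3 (within the scatter). The new compound also separates two changes that compound 1 carried together, and with 3-chlorophenyl kept, hydrogen in place of methyl gives the largest step of the set (a 13-fold higher number from compound 1 to compound 4 (1.10 log units; beyond the scatter)), so most of the low number of compound 1 goes with that methyl rather than with the chlorophenyl alone. Nothing measured here says why either step has its size.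

As far as these compounds go, it remains open how a 4-chlorophenyl or a plain phenyl would compare with 3-chlorophenyl at this place, and whether the methyl on the shared core would bring a similar fall to the methoxy and dimethylamino compounds. How a carboxylic acid or a primary amine on this outer ring would read in this assay is open as well.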